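The compounds below may be only part of what the source reports. "The series", "measured", "known", "first", "only" and "open" are said of these compounds alone.

Compound 1 `COc1cc(-c2nn(-c3cccc(NC(=O)c4cccc(C(F)(F)F)c4)c3)cc2-c2ccncc2)ccc1Cl` is one of two compounds with a value in a functional assay on TK-10 cells (Homo sapiens) for inhibition, read by sulforhodamine B assay, with a stated time of 48 h; a lower number here means that less compound is tolerated, a higher number that more compound is tolerated. In this assay compound 1 gives > 50000 nM, which is a limit of the assay rather than a number. Compound 2 `O=C(Nc1cccc(-n2cc(-c3ccncc3)c(-c3ccc(Cl)c(O)c3)n2)c1)Nc1ccc(Cl)c(C(F)(F)F)c1` is a related compound. In this assay compound 2 gives > 32500 nM, again a limit and not a number. For the measured compounds named here, compound 1 thus stands at the limit of > 50000 nM in this assay, at which 1 of the 2 values shown sits, and the only other value known sits at the limit of > 32500 nM in this assay, at which 1 of the 2 values shown sits. Compound 3 `COc1cc(-c2nn(-c3cccc(NC(=O)Nc4ccc(Cl)c(Cl)c4)c3)cc2-c2ccncc2)ccc1Cl` has not yet been measured in this assay. It differs from compound 1 in one place: (3,4-dichlorophenyl)amino in place of 3-(trifluoromethyl)phenyl on a carbonyl carbon. Going by the values given here, with both known values sitting at limits, no step of any size can be read from the measured compounds, so the change from compound 1 to compound 3 is expected to stay within the scatter, a number no higher from compound 1 to compound 3 (the limit leaves the size open). Compound 3 is therefore expected to give about 50000 nM in this assay, within 20000 nM to 100000 nM, most likely again reported only as a limit.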

Compound 3, concentration lethal to 50% of the cells: > 50000 nM
Compound 3: only a limit was reported; the forecaster's own chance of this, stated with the estimate: 75%; the middle value lies on the limit itself.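

Compound 3 gives > 50000 nM, which is a limit and not a number. For the compounds shown here, compound 1 also sits at a limit, so no step between compound 1 and compound 3 can be read. The compounds shown leave open whether (3,4-dichlorophenyl)amino in place of 3-(trifluoromethyl)phenyl changes the concentration lethal to the cells at all.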